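Chloro for methyl on the core of compound 3

The source may report more compounds than this note shows. Statements on the series, on what has been measured and on what is new or still open speak of the compounds shown alone.

Compound 3 `Cc1c[nH]c2ncnc(Nc3ccccc3-c3nnc[nH]3)c12` is the higher of the two numbers read in an assay on isolated protein for inhibition of RAC-alpha serine/threonine-protein kinase (Homo sapiens); on this read-out higher numbers stand for weaker inhibition and lower numbers for stronger inhibition: compound 3 gives 425 nM, while compound 1 `Clc1c[nH]c2ncnc(N3CCc4[nH]cnc4C3)c12`, built on the same core with a different amine, gives 42 nM. Compound 2 `Cn1ccc2c(Nc3ccccc3-c3nnc[nH]3)ncnc21` reaches only the limit of the assay, > 10000 nM, and returns no number. Compound 4 `Clc1c[nH]c2ncnc(Nc3ccccc3-c3nnc[nH]3)c12` differs from compound 3 in a single place: chloro in place of methyl on an aromatic carbon. For the measured compounds named here, no measured pair shows this exchange alone, so the size of the step is open. Compound 4 is estimated at 200 nM, within 60 nM to 700 nM. The step this implies, a 2.1-fold lower number from compound 3 to compound 4 (0.33 log units; beyond the scatter), is expected to be a small gain that may not exceed the scatter.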

Compound 4, half-maximal inhibitory concentration: 318 nM
Beside the measured number, compound 4's estimate is 1.6-fold (0.20 log units) below it; the range from low to high includes it.
By their numbers in this assay, from the lowest: compound 1; then compounds 4 and 3 (each within the scatter of the next). At a limit, above all of these: compound 2.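

In this assay, chloro in place of methyl on this aromatic carbon gives a 1.3-fold lower number from compound 3 to compound 4 (0.13 log units; within the scatter), so the two groups cannot be told apart at this position with this amine. For the compounds shown here, this is the first pair that isolates the exchange, and it shows that the exchange alone gives no step beyond the scatter. Nothing in the data on hand bears on why the two groups read alike.

Still open, as far as these compounds go, is how a nitrile, a methoxy or an amine would read on this carbon. Also open, from the compounds shown here alone, is whether chloro and methyl would match with the amine of compound 1.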